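The source may hold more compounds than are shown below. What is called first, only, known or untested is meant among the compounds shown, and "the series" means these compounds.

Working notes on the series. Compound 1 `CC(C)(C)c1ccc2c(c1)c(NO)cc[n+]2[O-]` and compound 2 `[O-][n+]1ccc(NO)c2cc(C3CCCCC3)ccc21` share a core and differ only in one substituent; in a physicochemical assay for lipophilicity (on this read-out higher numbers stand for higher lipophilicity and lower numbers for lower lipophilicity), compound 1 gives 2.05 and compound 2 gives 2.89, the higher of the two numbers, with a number 0.84 log units higher from compound 1 to compound 2 (beyond the scatter). Compound 3 `O=[N+]([O-])c1ccc2c(c1)c(NO)cc[n+]2[O-]` is the next member and is not yet measured in this assay. It differs from compound 2 by nitro in place of cyclohexyl on an aromatic carbon. Among the compounds with values here, the single measured step swaps one carbon group for another and so bears on the present change only as a bracket: compound 1 with 2.05 and compound 2 with 2.89 mark where two carbon groups on that position land. Within the data shown here, no measured step covers a carbon group leaving for nitro, so the expectation is set loosely, with a wide range. A downward step beyond the scatter is expected, a number 2.79 log units lower from compound 2 to compound 3 (beyond the scatter). For compound 3 the estimate in this assay is 0.1, within -0.6 to 0.8.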

Compound 3, partition coefficient: -0.28
Estimate against measurement, compound 3: 0.38 log units above, and the stated range covers the measured number.
By their numbers in this assay, from the lowest: compound 3; then compound 1; then compound 2.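

Nitro at this aromatic carbon moves the number far more than any exchange between carbon groups seen so far: this assay gives a number 3.17 log units lower from compound 2 to compound 3 (beyond the scatter) and a number 2.33 log units lower from compound 1 to compound 3 (beyond the scatter), both large, against the modest a number 0.84 log units higher from compound 1 to compound 2 (beyond the scatter). The position therefore responds strongly to the kind of group it carries, and the drop holds whether nitro replaces cyclohexyl or tert-butyl. Nothing at hand bears on what lies behind the size of these steps.

Within the data shown here, with nitro as the only group here that is not a carbon group, it remains open whether the large drop is peculiar to nitro or shared by other groups containing nitrogen or oxygen. An amine, a carboxylic acid or a methoxy group on this carbon could land close to compound 3 or much nearer to compound 1.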